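This account rests on a few compounds, and the source may have more. Where it says the series, first, only, none or still open, it means among the compounds named here.

Measured so far:
compound 1 `O=C1C=C(Nc2cccc(F)c2)C(=O)c2c1nc1n2[C@H]2OC[C@@H](O)[C@H]2OC1`: 2180 nM
compound 2 `CCCN(CCC)C1=CC(=O)c2c(nc3n2[C@H]2OC[C@@H](O)[C@H]2OC3)C1=O`: > 16000 nM

Among the compounds with values here, in a functional assay on MGC-803 cells (Homo sapiens) for inhibition, read by sulforhodamine B assay (on this read-out higher numbers stand for weaker inhibition and lower numbers for stronger inhibition), compound 1 gives 2180 nM, the only number among the values shown. Compound 2 returns > 16000 nM, which is a limit of the assay and not a number (the limit of > 16000 nM in this assay, at which 1 of the 2 values shown sits). No step between measured compounds differing in one place is shown, so the two values stand side by side without a counted step between them.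

Compound 3 `O=C1C=C(N2CCCC2)C(=O)c2c1nc1n2[C@H]2OC[C@@H](O)[C@H]2OC1` differs from compound 1 by pyrrolidin-1-yl in place of (3-fluorophenyl)amino on a double-bonded ring carbon. Compound 2 likewise carries a nitrogen with no hydrogen-bond donor at that ring carbon and sits at the limit, so the step from compound 1 to compound 3 is expected to weaken inhibition beyond the scatter, a 4.1-fold higher number from compound 1 to compound 3 (0.62 log units; beyond the scatter). Compound 3 is therefore estimated at 9000 nM, with a range from 3000 nM to 20000 nM, and a fair chance that only a limit is reported.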

Compound 3, half-maximal inhibitory concentration: > 16000 nM
Compound 3 gave a limit, no number; the forecaster's own chance of this, stated with the estimate: 40%; at least 1.7-fold (0.24 log units) between middle value and limit.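

In this assay, within the data shown here, pyrrolidin-1-yl in place of (3-fluorophenyl)amino on a double-bonded ring carbon gives an at least 7.3-fold higher number from compound 1 to compound 3 (0.86 log units; beyond the scatter), the first step that can be read. The (3-fluorophenyl)amino group of compound 1 therefore supports a measurable level of inhibition that does not survive this replacement. The value of compound 3 is a limit of the assay and not a number, so the step has a lower bound but no upper end, because the read-out stops there: the limit of > 16000 nM in this assay, at which 2 of the 3 values shown sit.

The change removes the hydrogen-bond donor and the aromatic ring together, so the step cannot assign the loss to either one. Cyclopentylamino, which keeps the nitrogen-bound hydrogen without the aromatic ring, and N-methyl-(3-fluorophenyl)amino, which keeps the ring without that hydrogen, would separate the two.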